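Formylphenyl on the benzyl series: a first estimate

The source may report more compounds than this note shows. Statements on the series, on what has been measured and on what is new or still open speak of the compounds shown alone.

Three compounds of the series have numbers in a functional assay on SNB-19 cells (Homo sapiens) for inhibition, read by sulforhodamine B assay, with a stated time of 48 h, tested at 10 uM; a lower number here means less inhibition, a higher number more inhibition at the concentration tested (going by the name of the read-out). Compound 1 `O=Cc1ccc(-c2cn3ccnc3c(-c3ccc4ncn(C5CCCCC5)c4c3)n2)cc1` carries a cyclohexyl group on the ring nitrogen and a 4-formylphenyl group on the shared core; in this assay compound 1 gives 14.4%. Compound 2 `CCc1ccc(-c2cn3ccnc3c(-c3ccc4ncn(Cc5ccccc5)c4c3)n2)cc1` carries a benzyl group instead and a 4-ethylphenyl group; compound 2 gives 20.9%. Compound 3 `Cc1cccc(-c2cn3ccnc3c(-c3ccc4ncn(Cc5ccccc5)c4c3)n2)c1` keeps the benzyl group and carries a 3-methylphenyl group; compound 3 gives 2.58%, the lowest of the three numbers, with the nearest neighbour being compound 1 and the furthest compound 2. Among the measured compounds shown here, the single step that changes the aryl group on the shared core is a number 18.3 percentage points lower from compound 2 to compound 3 (beyond the scatter).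

Compound 4 `O=Cc1ccc(-c2cn3ccnc3c(-c3ccc4ncn(Cc5ccccc5)c4c3)n2)cc1` is the next compound. Relative to compound 3 the change is 4-formylphenyl in place of 3-methylphenyl on an aromatic carbon. For the measured compounds named here, the only measured step at this position, the one from compound 2 to compound 3, was modest and downward toward the smaller aryl group; compound 4 goes the other way and takes the group that compound 1 carries. Compound 4 is therefore expected to rise, with a step of about a number 11.4 percentage points higher from compound 3 to compound 4 (beyond the scatter). The expected value for compound 4 is 14%, within a range from 2% to 28%.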

Compound 4, a percentage reported as inhibition, at one concentration (the size of the read-out at that concentration, not a potency): 14.4%
Beside the measured number, compound 4's estimate is 0.4 percentage points below it; low and high end bracket the measured number.
By their numbers in this assay, from the lowest: compound 3; then compounds 1, 4 and 2 (each within the scatter of the next).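

In this assay, among the compounds shown here, the 3-methylphenyl group is no longer the only partner for the step out of compound 2: a number 11.8 percentage points higher from compound 3 to compound 4 (beyond the scatter), so the low number of compound 3 is not shared by every aryl group tried on the benzyl series. Formyl and ethyl on the same phenyl group cannot be told apart, with a number 6.5 percentage points lower from compound 2 to compound 4 (within the scatter), which leaves compound 3 as the one compound of the benzyl series set off from both of its aryl neighbours. The ring nitrogen gets its first clean reading as well: with 4-formylphenyl held fixed, no change at the digits printed from compound 1 to compound 4 (within the scatter), so benzyl and cyclohexyl cannot be told apart on this aryl group, though that rests on this single pair.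

Still open, from the compounds shown here alone, is whether the low number of compound 3 belongs to the methyl group or to where it sits on the phenyl ring, and what an amine, a carboxylic acid or a longer chain would give on that phenyl ring. Nothing at hand offers a measured reason for the differences among these aryl groups.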